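The source may hold more compounds than are shown below. What is called first, only, known or untested is meant among the compounds shown, and "the series" means these compounds.

In a functional assay on A549 cells (Homo sapiens) for antiproliferative activity, read by sulforhodamine B assay, with a stated time of 72 h (on this read-out lower numbers stand for stronger inhibition and higher numbers for weaker inhibition), compound 1 (`O=C(/C=C/c1csc2ccccc12)c1cc(F)ccc1O`) gives 7100 nM while compound 2 (`Cc1ccc(O)c(C(=O)/C=C/c2csc3ccccc23)c1`) gives 4800 nM and compound 3 (`CCOc1ccc(O)c(C(=O)/C=C/c2csc3ccccc23)c1`) gives 5400 nM on the same core. Compound 3 lies within the scatter of both others, so the three cannot be ranked. Compound 4 (`CC(C)Oc1ccc(O)c(C(=O)/C=C/c2csc3ccccc23)c1`) differs from compound 3 by one change, ethoxy to isopropoxy (methyl in place of hydrogen on a saturated chain carbon bound to an oxygen on an aromatic ring and a saturated chain carbon). Changes to this aromatic substituent have stayed small: a 1.1-fold higher number from compound 2 to compound 3 (0.05 log units; within the scatter) for ethoxy against methyl, a 1.3-fold lower number from compound 1 to compound 3 (0.12 log units; within the scatter) for ethoxy against fluoro and a 1.5-fold lower number from compound 1 to compound 2 (0.17 log units; within the scatter) for methyl against fluoro. None leaves the scatter, so no step beyond it is expected in this assay for this change. The expected step is estimated as (a 1.1-fold lower number from compound 3 to compound 4 (0.03 log units; within the scatter)). Compound 4 is expected at 5000 nM within an estimated range from 2500 nM to 10000 nM in this read-out.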

Compound 4, half-maximal inhibitory concentration: 6400 nM
For compound 4 the middle estimate is 1.3-fold (0.11 log units) below the measured one; the range from low to high includes it.
By their numbers in this assay, from the lowest: compounds 2, 3, 4 and 1 (each within the scatter of the next).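

In this assay, the methyl placed on the saturated chain carbon bound to the oxygen turns ethoxy into the branched isopropoxy without leaving the scatter (a 1.2-fold higher number from compound 3 to compound 4 (0.07 log units; within the scatter)). The isopropoxy compound also stays within the scatter of the methyl and fluoro compounds (a 1.3-fold higher number from compound 2 to compound 4 (0.12 log units; within the scatter); a 1.1-fold lower number from compound 1 to compound 4 (0.05 log units; within the scatter)), so all four remain unranked. No measurement here explains these small steps. From the compounds shown here alone, whether a longer chain, an amine or a carboxylic acid on this aromatic carbon would produce a step beyond the scatter remains open.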